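The compounds below may be only part of what the source reports. "The series", "measured", "known", "first", "only" and "open" are said of these compounds alone.

Compound 1 `Fc1ccc(C2CC(c3ccc(Cl)s3)=NN2c2nc(-c3ccc(C(F)(F)F)cc3)cs2)cc1` is tested in an ADME assay on NIH3T3 cells (Mus musculus) for cytotoxicity, read by XTT assay, with a stated time of 24 h (a lower number here means a stronger inhibitor, a higher number a weaker inhibitor), where compound 1 gives > 500 ug/mL, which is a limit of the assay rather than a number. Compound 2 `Cc1ccc(C2=NN(c3nc(-c4ccc(C(F)(F)F)cc4)cs3)C(c3ccc(F)cc3)C2)s1` likewise gives > 500 ug/mL, again only a limit. Compound 3 `COc1ccc(-c2csc(N3N=C(c4ccc(C)s4)CC3c3ccc(F)cc3)n2)cc1` gives 147 ug/mL. Within the data shown here, the step that the two limits leave unreadable from compound 1 to compound 2 cannot be read, while the step of an at least 3.4-fold lower number from compound 2 to compound 3 (0.53 log units; beyond the scatter) is the only measured step that swaps the trifluoromethyl. Compound 4 `Cc1ccc(-c2csc(N3N=C(c4ccc(Cl)s4)CC3c3ccc(F)cc3)n2)cc1` differs from compound 1 by methyl in place of trifluoromethyl on an aromatic carbon. Since two of the three values sit at the limit of > 500 ug/mL in this assay, at which 2 of the 3 values shown sit, a plain number for compound 4 is uncertain, and methyl is not methoxy, so only a small move is expected. Compound 4 is expected to give around 320 ug/mL, between 120 ug/mL and 500 ug/mL. The expected step of an at least 1.5-fold lower number from compound 1 to compound 4 (0.19 log units; that floor lies within the scatter) is modest at most.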

Compound 4, half-maximal inhibitory concentration: > 500 ug/mL
Compound 4 gave a limit, no number; the forecaster's own chance of this, stated with the estimate: 50%; at least 1.5-fold (0.19 log units) between middle value and limit.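

Compound 1 and compound 4 both give only a limit of the assay, not a number, so no step between them can be read: the limit of > 500 ug/mL in this assay, at which 3 of the 4 values shown sit.

On these data alone, what methyl in place of trifluoromethyl does to the number in this assay remains open.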